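A few compounds are considered here, and "the series" means these few. Any claim that something is new, unique, unknown or untested is made for them only; others in the source may bear on it.

In a functional assay on CCRF-CEM cells (Homo sapiens) for antiproliferative activity, read by MTT assay, with a stated time of 48 h, tested at 50 uM (on this read-out higher numbers stand for a weaker effect at the one concentration tested and lower numbers for a stronger effect), compound 2 `C[C@@H](O)CCn1nc2c(Br)c(Br)c(Br)c(Br)c2n1` gives 23%, the highest of the three numbers seen so far, which on this read-out means the weakest effect at the one concentration tested. Compound 1 `OC(CCn1nc2c(Br)c(Br)c(Br)c(Br)c2n1)c1ccc(F)cc1` gives 0%, and compound 3 `OC(CCn1nc2c(Br)c(Br)c(Br)c(Br)c2n1)c1ccc(Cl)cc1` gives 0%; both of these stand beyond the scatter below compound 2. Going by the values given here, the only step between compounds that differ in one place, no change at the digits printed from compound 1 to compound 3 (within the scatter), concerns the aromatic ring that hangs from the chain and says nothing about the chain itself.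

Compound 4 `OCC(O)Cn1nc2c(Br)c(Br)c(Br)c(Br)c2n1` is yet to be measured. Relative to compound 2 the change is 1,2-dihydroxyethyl in place of 2-hydroxypropyl on a saturated chain carbon bound to an aromatic nitrogen. Among the compounds with values here, no measured step touches this part of the molecule, so the expectation rests only on the observation that compound 2, the sole compound with a short hydroxyalkyl chain and no aromatic ring on it, already gives 23%, while compound 1 and compound 3 carry a second ring and give lower numbers. Compound 4 keeps a short chain and gains a further hydroxyl, so it is expected to stay near compound 2, with at most a modest shift downward, a number 8 percentage points lower from compound 2 to compound 4 (within the scatter). For compound 4 the estimate in this assay is 15%, between 0% and 40%.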

Compound 4, a percentage reported as activity, at one concentration (the size of the read-out at that concentration, not a potency): 27%
Compound 4: the middle estimate sits 12 percentage points below what was measured; low and high end bracket the measured number.
By their numbers in this assay, from the lowest: compounds 1 and 3 (each within the scatter of the next); then compounds 2 and 4 (each within the scatter of the next).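

Going by these compounds alone, this is the first step that touches the chain rather than the ring hanging from it: in this assay, placing 1,2-dihydroxyethyl where 2-hydroxypropyl stood, on a saturated chain carbon bound to an aromatic nitrogen, gives a number 4 percentage points higher from compound 2 to compound 4 (within the scatter), so this read-out does not separate the two groups. The swap is not a small one on paper, since the entering group has 2 hydrogen-bond donors and 2 hydrogen-bond acceptors against 1 of each in the leaving group, and the 1 defined stereocentre of the leaving group goes with it, yet none of this shows up beyond the scatter at the one concentration tested. No supporting measurement bears on why the two groups read alike.

The compounds shown leave open whether an amine or a carboxylic acid on this chain, or a longer chain such as 3-hydroxybutyl carrying a further hydroxyl, would read the same. They also leave open whether compound 2 and compound 4 would match in potency, which a reading at a single concentration cannot tell.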